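Replacing 2-phenylethynyl with furan-3-yl on a shared core

The source may hold more compounds than are shown below. What is called first, only, known or untested is meant among the compounds shown, and "the series" means these compounds.

Three measured compounds share one core and differ in a single group. In a functional assay on CAPAN-1 cells (Homo sapiens) for antiproliferative activity, with a stated time of 72 h (on this read-out higher numbers stand for weaker inhibition and lower numbers for stronger inhibition), compound 1 `CCCCC#Cc1cc([C@@H]2O[C@H](CO)[C@@H](O)[C@H]2O)n2ncnc(N)c12` gives 1000 nM, compound 2 `Nc1ncnn2c([C@@H]3O[C@H](CO)[C@@H](O)[C@H]3O)cc(C#Cc3ccccc3)c12` gives 37700 nM and compound 3 `Nc1ncnn2c([C@@H]3O[C@H](CO)[C@@H](O)[C@H]3O)cc(-c3ccc(F)cc3F)c12` gives 50900 nM. Compound 2 therefore stands level with compound 3 and far from compound 1. The measured steps are a 1.4-fold higher number from compound 2 to compound 3 (0.13 log units; within the scatter) and a 38-fold higher number from compound 1 to compound 2 (1.58 log units; beyond the scatter).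

Compound 4 `Nc1ncnn2c([C@@H]3O[C@H](CO)[C@@H](O)[C@H]3O)cc(-c3ccoc3)c12` carries furan-3-yl in place of 2-phenylethynyl on an aromatic carbon. The closest guide is compound 3, where 2,4-difluorophenyl in place of 2-phenylethynyl gave only a 1.4-fold higher number from compound 2 to compound 3 (0.13 log units; within the scatter). The large jump of a 51-fold higher number from compound 1 to compound 3 (1.71 log units; beyond the scatter) shows that a change in this place can still matter greatly. Going by the values given here, no measured compound carries a five-membered aromatic ring in this place, so the uncertainty is wide.

In this assay, no clear step is expected, with only a slight lean towards stronger inhibition. The expected change is a 1.9-fold lower number from compound 2 to compound 4 (0.28 log units; within the scatter). Compound 4 is estimated at 20000 nM, with an expected range of 3000 nM to 60000 nM.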

Compound 4, half-maximal inhibitory concentration: 900 nM
Compound 4: the middle estimate sits 22-fold (1.35 log units) above what was measured; measured number outside the range, below it.
By their numbers in this assay, from the lowest: compounds 4 and 1 (each within the scatter of the next); then compounds 2 and 3 (each within the scatter of the next).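

In this assay, the aromatic carbon two ring bonds from the ring nitrogen does not treat all aromatic rings alike: furan-3-yl gives a 42-fold lower number from compound 2 to compound 4 (1.62 log units; beyond the scatter) and a 57-fold lower number from compound 3 to compound 4 (1.75 log units; beyond the scatter), so the level shared by compound 2 and compound 3 does not hold for every ring placed here. The step of a 1.1-fold lower number from compound 1 to compound 4 (0.05 log units; within the scatter) also puts this five-membered aromatic ring level with the hex-1-yn-1-yl chain, so the earlier gap between that chain and the two groups with six-membered rings does not apply to every ring-bearing group. Nothing available explains the difference between furan-3-yl and those two groups.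

The compounds shown leave open whether the oxygen of furan-3-yl matters or whether any five-membered aromatic ring would do, a question that thiophen-3-yl, with sulfur in place of oxygen, could help answer. On these data alone, whether furan-2-yl, or an amine on this carbon, would behave the same way also remains open.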